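Solubility notes: urea to thiophene amide on shared core

This account rests on a few compounds, and the source may have more. Where it says the series, first, only, none or still open, it means among the compounds named here.

Measured so far:
compound 1 `CN1CCC(C(=O)N2Cc3c(NC(=O)Nc4cccc(F)c4)n[nH]c3C2(C)C)CC1` — > 225000 nM
compound 2 `CCCNC(=O)Nc1n[nH]c2c1CN(C(=O)C1CCN(C)CC1)C2(C)C` — > 225000 nM

In a physicochemical assay for solubility, at pH 7 (on this read-out higher numbers stand for higher solubility and lower numbers for lower solubility), compound 1 reaches only a limit, > 225000 nM. Compound 2 likewise stops at a limit in this assay, > 225000 nM. The step that the two limits leave unreadable from compound 1 to compound 2 is thus unreadable, since both values sit at the limit of > 225000 nM in this assay, at which 2 of the 2 values shown sit. Compound 2 therefore stands at the top of what the numbers show, with no readable distance to compound 1.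

Compound 3 `CN1CCC(C(=O)N2Cc3c(NC(=O)c4cccs4)n[nH]c3C2(C)C)CC1` differs from compound 2 by thiophen-2-yl in place of propylamino on a carbonyl carbon. For the measured compounds named here, no measured step covers this change: the only step available, a step that the two limits leave unreadable from compound 1 to compound 2, carries no size that could be transferred. For compound 3 the solubility in this assay is estimated at 150000 nM, with a range from 40000 nM to 225000 nM. The expected step is an at least 1.5-fold lower number from compound 2 to compound 3 (0.17 log units; that floor lies within the scatter), with a fair chance that only a limit is reported again.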

Compound 3, solubility: 155000 nM
Estimate against measurement, compound 3: 1.0-fold (0.01 log units) below; measured number inside the range.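

For the compounds shown here, compound 3 is the first compound on the shared core to give a number rather than a limit in this assay, so changes at this carbonyl carbon can now be given a size, though only as a floor. Thiophen-2-yl in place of propylamino gives an at least 1.4-fold lower number from compound 2 to compound 3 (0.16 log units; that floor lies within the scatter), and thiophen-2-yl in place of (3-fluorophenyl)amino gives an at least 1.4-fold lower number from compound 1 to compound 3 (0.16 log units; that floor lies within the scatter). The step between the two amino-substituted compounds still cannot be read: the limit of > 225000 nM in this assay, at which 2 of the 3 values shown sit.

From the compounds shown here alone, the true size of both steps stays open, as each is only a floor set by a limit. Also open, going by these compounds, is where a phenyl, a furan-2-yl or a dimethylamino group on the same carbonyl carbon would fall in this assay relative to compound 3.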